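Swapping the ester tail: cyanomethyl gives way to 4-nitrophenyl

This account rests on a few compounds, and the source may have more. Where it says the series, first, only, none or still open, it means among the compounds named here.

Compound 1 `C=CCn1c(=O)c(CCO)c(-c2ccccc2Cl)c2cc(Cl)ccc21`: 23000 nM
Compound 2 `O=c1c(CCO)c(-c2ccccc2Cl)c2cc(Cl)ccc2n1-c1ccccc1`: 26000 nM
Compound 3 `N#CCC(=O)OCCc1c(-c2ccccc2Cl)c2cc(Cl)ccc2[nH]c1=O`: 100000 nM

These three compounds were tested in an ADME assay on HepG2 2.2.15 cells (Homo sapiens) for cytotoxicity; on this read-out higher numbers stand for lower toxicity in this test and lower numbers for higher toxicity in this test. Compound 3 gives the highest number of the three; its nearest neighbour is compound 2, and compound 1 lies furthest away, both gaps beyond the scatter. Compound 4 `O=C(OCCc1c(-c2ccccc2Cl)c2cc(Cl)ccc2[nH]c1=O)c1ccc([N+](=O)[O-])cc1` differs from compound 3 at the ester: 4-nitrophenyl in place of cyanomethyl on a carbonyl carbon. For the measured compounds named here, the only measured step, a 1.1-fold higher number from compound 1 to compound 2 (0.05 log units; within the scatter), concerns a substituent on an aromatic nitrogen, a different place, so it does not speak to this change. Going by the values given here, no measured step therefore bears on the step to compound 4, and no shift beyond the scatter is expected, a 1.3-fold lower number from compound 3 to compound 4 (0.10 log units; within the scatter). Compound 4 is estimated at 80000 nM, with a range of 30000 nM to 200000 nM.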

Compound 4, half-maximal cytotoxic concentration: 1600000 nM
For compound 4 the middle estimate is 20-fold (1.30 log units) below the measured one; the measured number lies above the stated range.
By their numbers in this assay, from the lowest: compounds 1 and 2 (each within the scatter of the next); then compound 3; then compound 4.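

In this assay the group on the ester carbonyl carbon proves to matter: 4-nitrophenyl in place of cyanomethyl gives a 16-fold higher number from compound 3 to compound 4 (1.20 log units; beyond the scatter), a large step towards lower toxicity in this test. For the compounds shown here, the earlier compounds held no step at this position, so this is the first sign that the ester tail can move this read-out so far. Nothing measured here explains the shift. Still open, as far as these compounds go, is whether the aromatic ring alone carries the step or whether its nitro group is needed. An unsubstituted phenyl or a simple methyl on the same carbonyl would help separate these possibilities.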